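Ring nitrogen methyl to hydrogen across two dibromopyrrole enones

The source may report more compounds than this note shows. Statements on the series, on what has been measured and on what is new or still open speak of the compounds shown alone.

Compound 1 `Cn1c(/C=C/C(=O)c2ccc[nH]2)cc(Br)c1Br` is the reference; in a functional assay on KB403 cells (Homo sapiens) for cytotoxicity, read by MTT assay, with stated times of 6 h and 48 h (a lower number here means a stronger inhibitor, a higher number a weaker inhibitor), compound 1 gives 600 nM. Compound 3 `O=C(/C=C/c1cc(Br)c(Br)[nH]1)c1ccc[nH]1` carries hydrogen in place of methyl on an aromatic nitrogen. In this assay compound 3 gives only a limit, >= 100000 nM. The step is an at least 160-fold higher number from compound 1 to compound 3 (2.22 log units; beyond the scatter), ending at the limit of >= 100000 nM in this assay, at which 2 of the 3 values shown sit. Compound 2 `COc1ccc(OC)c(C(=O)/C=C/c2cc(Br)c(Br)n2C)c1` has a different core; the difference between the two cores is not broken down here. In this assay compound 2 gives only a limit, >= 100000 nM. Compound 4 `COc1ccc(OC)c(C(=O)/C=C/c2cc(Br)c(Br)[nH]2)c1` is not yet measured and differs from compound 2 by hydrogen in place of methyl on an aromatic nitrogen. This is the same kind of change as from compound 1 to compound 3, the place now described as next to the ring atom that bears a large group rather than a group of 9 heavy atoms. Since compound 2 already sits at the limit of >= 100000 nM in this assay, at which 2 of the 3 values shown sit, and the earlier step of an at least 160-fold higher number from compound 1 to compound 3 (2.22 log units; beyond the scatter) moved toward weaker inhibition, compound 4 is expected to stay at the limit, estimated at 100000 nM. The expected step is a number no higher from compound 2 to compound 4 (the limit leaves the size open).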

Compound 4, half-maximal inhibitory concentration: >= 100000 nM
Compound 4: a limit, no number; the forecaster's own chance of this, stated with the estimate: 90%; the middle value sits exactly at the limit.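

Among the compounds shown here, compound 2 and compound 4 both give only limits, so no step between them can be read: the limit of >= 100000 nM in this assay, at which 3 of the 4 values shown sit.

The compounds shown leave open whether hydrogen in place of methyl on an aromatic nitrogen changes inhibition at all on the core of compound 2.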